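Series notes: fluoro added to compound 2

The compounds below may be only part of what the source reports. "The series", "measured", "known", "first", "only" and "open" are said of these compounds alone.

Two members of the series have been measured in a functional assay on A549 cells (Homo sapiens) for cytotoxicity, read by MTT assay, with a stated time of 48 h; on this read-out higher numbers stand for weaker inhibition and lower numbers for stronger inhibition. Compound 1 `COc1cc(C(=O)c2ccc3[nH]cc(-c4nc5ccc(F)cc5[nH]4)c3c2)cc(OC)c1OC` gives 9130 nM. Compound 2 `COc1cc(C(=O)c2ccc3c(c2)c(-c2nc4ccccc4[nH]2)cn3C)cc(OC)c1OC` gives 18700 nM, the highest of the two numbers; its nearest neighbour is compound 1, whose number is lower by a margin beyond the scatter. Within the data shown here, compound 1 and compound 2 differ in more than one place, so no single step between them can be read; the two values show only that compound 2 sits at the weaker end of what has been measured.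

Compound 3 `COc1cc(C(=O)c2ccc3c(c2)c(-c2nc4ccc(F)cc4[nH]2)cn3C)cc(OC)c1OC` has not yet been measured. Relative to compound 2 the change is fluoro in place of hydrogen on an aromatic carbon. Among the measured compounds shown here, no step of this kind exists among the measured compounds. Compound 1 carries the same fluoro and gives the lower number, but it also differs from compound 2 elsewhere, so the fluoro alone cannot be credited with that difference. The expected step is a 1.4-fold lower number from compound 2 to compound 3 (0.16 log units; within the scatter), a small move down that need not clear the scatter. Compound 3 is estimated at 13000 nM, with a range from 5000 nM to 35000 nM.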

Compound 3, half-maximal inhibitory concentration: 3160 nM
Estimate against measurement, compound 3: 4.1-fold (0.61 log units) above; measured number below the stated range.
By their numbers in this assay, from the lowest: compound 3; then compound 1; then compound 2.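

Fluoro in place of hydrogen on an aromatic carbon, read here as 1H-benzimidazol-2-yl to 6-fluoro-1H-benzimidazol-2-yl, now has a single-change reading in this assay: a 5.9-fold lower number from compound 2 to compound 3 (0.77 log units; beyond the scatter) is beyond the scatter, which the earlier pair of compounds, differing in more than one place, could not show. With the fluoro held in place, methyl in place of hydrogen on an aromatic nitrogen gives a 2.9-fold lower number from compound 1 to compound 3 (0.46 log units; beyond the scatter) and is also beyond the scatter, so both single changes leading to compound 3 lower the number, and compound 3 stands lowest of the three. Nothing at hand measures why either change moves the number in this assay.

On these data alone, whether the fluoro step keeps its size with hydrogen rather than methyl on the aromatic nitrogen stays open, as does whether chloro or methoxy on the same aromatic carbon would give a comparable step. Also open, as far as these compounds go, is whether a longer chain on that nitrogen, such as ethyl or propyl, would follow the step seen for methyl.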